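Phenoxy for allylamino on the shared pyrazine-free core

The compounds below may be only part of what the source reports. "The series", "measured", "known", "first", "only" and "open" are said of these compounds alone.

Compound 1 `C=CCNc1nc(N)c(C(=O)N=C(N)N)nc1Cl` is the reference point of this set. In an assay for inhibition of acid-sensing ion channel 3 (Homo sapiens), read by patch clamp, tested at 1 uM (a lower number here means less inhibition, a higher number more inhibition at the concentration tested (going by the name of the read-out)), compound 1 gives 16%, the lower of the two numbers in hand. Compound 3 `NC(N)=NC(=O)c1nc(Cl)c(N2CCc3ccccc32)nc1N` gives 46% in this assay, a reading higher than that of compound 1 by a margin beyond the usual scatter. Compound 2 `CN1CCN(c2nc(N)c(C(=O)N=C(N)N)nc2Cl)CC1` has no result in this assay "not determined" (no result reported), so it adds nothing to the comparison.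

Compound 4 `NC(N)=NC(=O)c1nc(Cl)c(Oc2ccccc2)nc1N` has not been measured. Relative to compound 1 the change is phenoxy in place of allylamino on an aromatic carbon. Going by the values given here, no measured pair shows this exact exchange, so the expectation rests only on the two numbers present: compound 1 at 16% and compound 3 at 46%, the latter carrying a larger group with an aromatic ring at the same position.

For compound 4 the step of a number 14 percentage points higher from compound 1 to compound 4 (beyond the scatter) is expected to run upward, at the edge of the scatter. Compound 4 is therefore estimated at 30% in this assay, within a range from 10% to 55%.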

Compound 4, a percentage reported as inhibition, at one concentration (the size of the read-out at that concentration, not a potency): 23%
Compound 4: the middle estimate sits 7 percentage points above what was measured; measured number inside the range.
By their numbers in this assay, from the lowest: compounds 1 and 4 (each within the scatter of the next); then compound 3.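

In this assay, phenoxy in place of allylamino on an aromatic carbon gives a number 7 percentage points higher from compound 1 to compound 4 (within the scatter). This exchange brings in a six-membered aromatic ring of carbon only and drops the hydrogen-bond donor of allylamino, yet the reading does not separate from that of compound 1, so an aromatic ring at this position does not by itself give the reading of compound 3 at 46% in this assay. Nothing available explains this result.

Open, on these data alone, is whether the nitrogen link of compound 3 matters more than the aromatic ring it carries, which an anilino group in this position would test against phenoxy. A benzyloxy group would show whether a longer link from the shared core to the ring changes the reading.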